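The source may report more compounds than this note shows. Statements on the series, on what has been measured and on what is new or still open speak of the compounds shown alone.

Of the compounds shown here, three with a shared core have been measured in a functional assay on A2780 cells (Homo sapiens) for antiproliferative activity, read by sulforhodamine B assay, with a stated time of 72 h; on this read-out higher numbers stand for weaker inhibition and lower numbers for stronger inhibition. Compound 1 `COc1cccc(S(=O)(=O)c2ccc(CN/C(=N\C#N)Nc3ccncc3)cc2)c1` gives 3.4 nM. Compound 2 `N#C/N=C(\NCc1ccc(S(=O)(=O)c2cccc(C(F)(F)F)c2)cc1)Nc1ccncc1` gives 2.9 nM. Compound 3 `N#C/N=C(\NCc1ccc(S(=O)(=O)c2ccccc2)cc1)Nc1ccncc1` gives 9.7 nM. On these numbers compound 1 stands second highest of the three, with compound 2 nearest and compound 3 furthest away; the step of a 1.2-fold lower number from compound 1 to compound 2 (0.07 log units; within the scatter) lies within the scatter, so compounds 1 and 2 cannot be told apart on this read-out.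

Compound 4 `N#C/N=C(\NCc1ccc(S(=O)(=O)C2CCCCC2)cc1)Nc1ccncc1` differs from compound 1 in one place: cyclohexyl in place of 3-methoxyphenyl on a sulfonyl sulfur. Among the measured compounds shown here, no measured step exchanges an aromatic ring for a non-aromatic one on this sulfonyl sulfur, so the nearest guides are the steps that strip a substituent from that ring. The step of a 2.9-fold higher number from compound 1 to compound 3 (0.46 log units; beyond the scatter) and the step of a 3.3-fold higher number from compound 2 to compound 3 (0.52 log units; beyond the scatter) are both modest and both go toward a higher number. Replacing the whole ring, rather than only its substituent, is a larger change than either of those, so a step at least as large as those, and probably larger, toward a higher number in this assay is expected.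

Compound 4 is therefore estimated at 35 nM, with a likely range from 8 nM to 150 nM, which would be a step of a 10-fold higher number from compound 1 to compound 4 (1.01 log units; beyond the scatter).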

Compound 4, half-maximal inhibitory concentration: 14.8 nM
The estimate for compound 4 lay 2.4-fold (0.37 log units) above the measured number, within the range that was stated.
By their numbers in this assay, from the lowest: compounds 2 and 1 (each within the scatter of the next); then compounds 3 and 4 (each within the scatter of the next).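

Cyclohexyl in place of phenyl on the sulfonyl sulfur gives a 1.5-fold higher number from compound 3 to compound 4 (0.18 log units; within the scatter) in this assay, so an aromatic ring at this place is not required for a value that cannot be told apart from that of the unsubstituted phenyl compound. The two steps from the substituted rings are both modest, a 4.4-fold higher number from compound 1 to compound 4 (0.64 log units; beyond the scatter) and a 5.1-fold higher number from compound 2 to compound 4 (0.71 log units; beyond the scatter), which places the visible divide in this small set between the 3-methoxyphenyl and 3-(trifluoromethyl)phenyl compounds on one side and the phenyl and cyclohexyl compounds on the other. No other measurement accompanies these numbers, and so nothing here can say what lies behind this pattern.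

The compounds shown leave open whether a methoxy or trifluoromethyl group on the cyclohexyl ring would match what those groups do on the phenyl ring, since only the unsubstituted cyclohexyl ring appears here. They also leave open how far this tolerance extends, for example to a smaller cyclopropyl ring, an open-chain hexyl group, or a cyclohexyl ring carrying an amine or a carboxylic acid.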